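The source may report more compounds than this note shows. Statements on the series, on what has been measured and on what is new or still open speak of the compounds shown alone.

Three analogues of one core have numbers in an ADME assay on MT4 cells (Homo sapiens) for cytotoxicity, read by MTT assay, with a stated time of 4 days; a higher number here means that more compound is tolerated, a lower number that less compound is tolerated. Compound 1 `CNc1nc(Nc2ccc(C#N)cc2)nc(Oc2ccc3ccccc3c2)n1` gives 250000 nM, compound 3 `CNc1nc(Nc2ccc(C#N)cc2)nc(Oc2ccc3ccccc3c2Br)n1` gives 143000 nM, and compound 2 `N#Cc1ccc(Nc2nc(N)nc(Oc3ccc4ccccc4c3)n2)cc1` gives 42200 nM, the lowest of the three, with compound 3 the nearest and compound 1 the furthest, both beyond the scatter. Compound 4 `N#Cc1ccc(Nc2nc(N)nc(Oc3ccc4ccccc4c3Cl)n2)cc1` differs from compound 2 by chloro in place of hydrogen on an aromatic carbon. The closest comparison is a 1.7-fold lower number from compound 1 to compound 3 (0.24 log units; within the scatter), a halogen at the same place that stayed within the scatter. Within the data shown here, no step with chloro itself is available. On that basis, a step of a 1.2-fold lower number from compound 2 to compound 4 (0.08 log units; within the scatter) is expected, that is, little or no change beyond the scatter. Compound 4 is therefore estimated at 35000 nM, in the range 15000 nM to 90000 nM.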

Compound 4, half-maximal cytotoxic concentration: 32200 nM
For compound 4 the middle estimate is 1.1-fold (0.04 log units) above the measured one, within the range that was stated.
By their numbers in this assay, from the lowest: compounds 4 and 2 (each within the scatter of the next); then compounds 3 and 1 (each within the scatter of the next).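

In this assay, chloro in place of hydrogen on an aromatic carbon ortho to a fused ring gives a 1.3-fold lower number from compound 2 to compound 4 (0.12 log units; within the scatter). Alongside a 1.7-fold lower number from compound 1 to compound 3 (0.24 log units; within the scatter), this shows a halogen at this position staying within the scatter with either hydrogen or methyl on the nitrogen, not only with methyl. No measured evidence explains this result.

From the compounds shown here alone, whether a non-halogen group at this position, such as methoxy, an amine or a carboxylic acid, also stays within the scatter remains open. Chloro and bromo also remain without a direct comparison on one shared core.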